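Methyl on the pendant phenyl of the tetrahydroquinolinol core

The source may report more compounds than this note shows. Statements on the series, on what has been measured and on what is new or still open speak of the compounds shown alone.

Compound 1, `O[C@@H]1Cc2ccccc2N[C@H](c2ccccc2)C1`, is the parent of this small set. In an ADME assay on Vero cells (Chlorocebus sabaeus) for cytotoxicity, read by MTT assay, with a stated time of 72 h (a lower number here means that less compound is tolerated, a higher number that more compound is tolerated), compound 1 gives > 300000 nM, which is a limit of the assay and not a number. Compound 2, `O[C@@H]1Cc2cc(OC(F)(F)F)ccc2N[C@H](c2ccccc2)C1`, carries a trifluoromethoxy group and in this assay compound 2 gives 124000 nM; this makes an at least 2.4-fold lower number from compound 1 to compound 2 (0.38 log units; beyond the scatter). Because (the limit of > 300000 nM in this assay, at which 1 of the 2 values shown sits), the true size of that step is not known. Among the measured compounds shown here, compound 3, `Cc1cccc([C@@H]2C[C@H](O)Cc3ccccc3N2)c1`, differs from compound 1 by methyl in place of hydrogen on an aromatic carbon, a change on the other aromatic ring than the one altered in compound 2. For the measured compounds named here, the single measured step, the one from compound 1 to compound 2, is the only guide and it describes a larger group at a different place, so only a small downward step or none beyond the scatter is expected here. The number for compound 3 in this assay is therefore estimated at 250000 nM (range 100000 nM to 300000 nM), which would be a step of an at least 1.2-fold lower number from compound 1 to compound 3 (0.07 log units; that floor lies within the scatter) and is expected to stay near the limit.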

Compound 3, half-maximal cytotoxic concentration: > 300000 nM
Compound 3: no number, only a limit; the forecaster's own chance of this, stated with the estimate: 55%; middle value at least 1.2-fold (0.07 log units) from the limit.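

Among the compounds shown here, for compound 1 and compound 3, this assay gives only a limit and not a number, so no step between them can be read: the limit of > 300000 nM in this assay, at which 2 of the 3 values shown sit. The compounds shown leave open whether methyl in place of hydrogen on an aromatic carbon changes the number in this assay at all.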